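Swapping pyrrolidin-1-yl for diethylamino in compound 2

A few compounds are considered here, and "the series" means these few. Any claim that something is new, unique, unknown or untested is made for them only; others in the source may bear on it.

Measured so far in a functional assay on MCF7 cells (Homo sapiens) for inhibition; a higher number here means a weaker inhibitor, a lower number a stronger inhibitor

Compound 1 (`CCN(CC)CCNC(=O)CC(CC(=O)NC1Cc2ccccc2C1)c1ccc(Cl)cc1`) gives 75000 nM
Compound 2 (`CCN(C(=O)CC(CC(=O)NCCN1CCCC1)c1ccc(Cl)cc1)C1Cc2ccccc2C1`) gives 20400 nM

Of the two measured compounds, compound 2 holds the lower number and is the stronger inhibitor, while compound 1 sits higher by a gap beyond the usual scatter of repeated measurements. Attention now turns to compound 3 (`CCN(CC)CCNC(=O)CC(CC(=O)N(CC)C1Cc2ccccc2C1)c1ccc(Cl)cc1`), which has not yet been measured. It is reached from compound 2 by a single exchange (diethylamino in place of pyrrolidin-1-yl on a saturated chain carbon, two bonds along the chain from an amide-type nitrogen), with diethylamino in place of pyrrolidin-1-yl on a saturated chain carbon, two bonds along the chain from an amide-type nitrogen.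

Among the measured compounds shown here, no pair of measured compounds shows this exchange on its own, so the data give no direct size for it. In this assay a step no larger than the scatter is expected, with no firm direction. The estimate amounts to a 1.2-fold higher number from compound 2 to compound 3 (0.09 log units; within the scatter) as the expected step. Compound 3 is expected at 25000 nM (estimated range 10000 nM to 60000 nM).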

Compound 3, half-maximal inhibitory concentration: 23000 nM
For compound 3 the middle estimate is 1.1-fold (0.04 log units) above the measured one; measured number inside the range.
By their numbers in this assay, from the lowest: compounds 2 and 3 (each within the scatter of the next); then compound 1.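

In this assay, the exchange of pyrrolidin-1-yl for diethylamino on a saturated chain carbon, two bonds along the chain from an amide-type nitrogen, gives a 1.1-fold higher number from compound 2 to compound 3 (0.05 log units; within the scatter), so the closed ring of compound 2 and the open diethylamino group of compound 3 cannot be told apart at this position in this assay. Compound 3 also provides the one-place link that the earlier pair lacked: ethyl in place of hydrogen on an amide-type nitrogen gives a 3.3-fold lower number from compound 1 to compound 3 (0.51 log units; beyond the scatter), and this separates the effect of that ethyl group from the amine exchange, which compound 1 and compound 2 carried together. Nothing measured here explains either step.

Going by these compounds, both steps rest on a single pair of compounds each, so it remains open whether the ethyl effect carries over to other settings, or whether a propyl or benzyl group on the same amide-type nitrogen would extend it. On these data alone, it is equally open whether piperidin-1-yl or morpholin-4-yl would match diethylamino and pyrrolidin-1-yl at the chain position, or whether the match holds only for these two amines.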